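Swapping the Ester-Side Group on the Shared Core

This account rests on a few compounds, and the source may have more. Where it says the series, first, only, none or still open, it means among the compounds named here.

Measured so far in an assay on HEK293 cells for displacement of a labelled ligand from NPC1-like intracellular cholesterol transporter 1 (Homo sapiens); on this read-out lower numbers stand for stronger inhibition and higher numbers for weaker inhibition:
compound 1, `CC(C)(C)OC(=O)NCCCNC(=O)CN1CN(c2ccccc2)C2(CCN(C(=O)c3ccc(C(C)(C)C)cc3)CC2)C1=O`: 4500 nM
compound 2, `CC(C)(C)c1ccc(C(=O)N2CCC3(CC2)C(=O)N(CC(=O)N2CCCCC2CCO)CN3c2ccccc2)cc1`: 6100 nM
compound 3, `CC1(C)CC(OC(=O)CN2CN(c3ccccc3)C3(CCN(C(=O)c4ccc(C(C)(C)C)cc4)CC3)C2=O)CC(C)(C)N1`: 1300 nM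

All three share one core and differ only in the group attached to a carbonyl carbon on a short side chain. Compound 3 stands lowest of the three numbers in this assay, reached by a 3.5-fold lower number from compound 1 to compound 3 (0.54 log units; beyond the scatter) and by a 4.7-fold lower number from compound 2 to compound 3 (0.67 log units; beyond the scatter). Compound 1 and compound 2 lie close together, as shown by a 1.4-fold higher number from compound 1 to compound 2 (0.13 log units; within the scatter).

Compound 4, `CC(C)(C)c1ccc(C(=O)N2CCC3(CC2)C(=O)N(CC(=O)NCCCCN)CN3c2ccccc2)cc1`, differs from compound 3 by (4-aminobutyl)amino in place of (2,2,6,6-tetramethylpiperidin-4-yl)oxy on a carbonyl carbon. Both measured steps toward compound 3 put the (2,2,6,6-tetramethylpiperidin-4-yl)oxy group in place of a group joined through nitrogen, and both lowered the number modestly. The move to compound 4 reverses that kind of change, though to a group not yet seen, so a modest rise is expected. For compound 4 the estimate in this assay is 3500 nM, spanning 1200 nM to 10000 nM, corresponding to an expected step of a 2.7-fold higher number from compound 3 to compound 4 (0.43 log units; beyond the scatter).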

Compound 4, half-maximal inhibitory concentration: 14500 nM
Compound 4: the middle estimate sits 4.1-fold (0.62 log units) below what was measured; measured number outside the range, above it.
By their numbers in this assay, from the lowest: compound 3; then compounds 1 and 2 (each within the scatter of the next); then compound 4.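

In this assay, among these compounds, this is the largest step seen so far at this carbonyl carbon (an 11-fold higher number from compound 3 to compound 4 (1.05 log units; beyond the scatter)), so replacing the (2,2,6,6-tetramethylpiperidin-4-yl)oxy group can cost more than the earlier comparisons showed. Compound 4 also stands apart from the two other compounds with nitrogen-joined groups, which lay within the scatter of each other (a 2.4-fold higher number from compound 2 to compound 4 (0.38 log units; beyond the scatter); a 3.2-fold higher number from compound 1 to compound 4 (0.51 log units; beyond the scatter)), and the second of these steps shows that changing only the chain end, from (tert-butoxycarbonyl)amino to aminomethyl, is enough to shift the number. No independent evidence here accounts for these shifts.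

Still open, on these data alone, is whether the rise follows the nitrogen link, the flexible chain or its free amine end. A 4-aminobutyl ester, or the same chain ending in a carboxylic acid, would help separate these possibilities.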